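Swapping Fluoro for Chloro: From Compound 3 to Compound 4

This account rests on a few compounds, and the source may have more. Where it says the series, first, only, none or still open, it means among the compounds named here.

The three measured compounds share one core, and in an ADME assay on NIH3T3 cells (Mus musculus) for cytotoxicity, read by MTT assay, with a stated time of 24 h (on this read-out higher numbers stand for weaker inhibition and lower numbers for stronger inhibition), they run as follows. Compound 1 `O=C(CSc1nnnn1-c1ccccc1)N/N=c1/scc(-c2ccc(Cl)cc2)n1-c1ccccc1` gives 313 ug/mL. Compound 2 `Cn1nnnc1SCC(=O)N/N=c1/scc(-c2ccc(C#N)cc2)n1-c1ccccc1` gives 213 ug/mL. Compound 3 `Cn1nnnc1SCC(=O)N/N=c1/scc(-c2ccc(F)cc2)n1-c1ccccc1` gives 113 ug/mL, the lowest of the three numbers: compound 2 sits nearest, within the scatter, and compound 1 sits furthest, beyond it. Within the data shown here, the single measured step that changes only the group on the aromatic ring is a 1.9-fold lower number from compound 2 to compound 3 (0.28 log units; within the scatter).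

Compound 4 `Cn1nnnc1SCC(=O)N/N=c1/scc(-c2ccc(Cl)cc2)n1-c1ccccc1` differs from compound 3 by one group: chloro in place of fluoro on an aromatic carbon. Among the measured compounds shown here, no measured pair tests exactly this exchange; compound 1 also carries chloro, but it differs from compound 4 in a second place as well, so its value can only be read as a loose pointer. Given that the one comparable step, from cyano to fluoro, stayed within the scatter, the change to chloro in compound 4 is expected to give a step of a 1.3-fold higher number from compound 3 to compound 4 (0.12 log units; within the scatter) in this assay, that is, no shift beyond the scatter. Compound 4 is therefore estimated at 150 ug/mL, with a range from 70 ug/mL to 330 ug/mL.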

Compound 4, half-maximal inhibitory concentration: 40 ug/mL
For compound 4 the middle estimate is 3.8-fold (0.57 log units) above the measured one, and the stated range ends above it.
By their numbers in this assay, from the lowest: compound 4; then compounds 3, 2 and 1 (each within the scatter of the next, the first and the last beyond it).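

Among these compounds, the exchange of fluoro for chloro on the aromatic carbon gave the first single-group step at this position to lie beyond the scatter in this assay (a 2.8-fold lower number from compound 3 to compound 4 (0.45 log units; beyond the scatter)), and chloro in place of cyano at the same place gave a larger one (a 5.3-fold lower number from compound 2 to compound 4 (0.73 log units; beyond the scatter)), so the identity of this group can move the number, which the step from cyano to fluoro could not show. Among the compounds shown here, the first measured change at the aromatic nitrogen, with the chloro held fixed, showed that this second place also matters: methyl in place of phenyl gave a step beyond the scatter (a 7.8-fold lower number from compound 1 to compound 4 (0.89 log units; beyond the scatter)). No measurement at hand accounts for either effect.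

The compounds shown leave open how bromo, methoxy or an amine would read at the same place on the ring. They also leave open whether an ethyl group on the aromatic nitrogen would follow methyl or phenyl, and whether the gap between chloro and fluoro persists with phenyl there.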